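Adding a methyl group to compound 3

The source may hold more compounds than are shown below. What is called first, only, known or untested is meant among the compounds shown, and "the series" means these compounds.

compound 1 `CN1CCN(CC#CCn2ccnc2)C1=O` gives 1.4 mg/kg
compound 2 `Cn1ccn(CC#CCN2CCCC2)c1=O` gives 6.6 mg/kg
compound 3 `Cn1ccn(CC#CCn2ccnc2)c1=O` gives 4.4 mg/kg

In a functional assay on the whole organism for agonist activity, with Mus musculus as the target (on this read-out higher numbers stand for an effect only at larger amounts of compound and lower numbers for an effect already at smaller amounts), compound 3 lies within the scatter of compound 2, while compound 1 gives a lower number, beyond the scatter. Compound 3 therefore sits with compound 2 in the upper part of the three numbers.

Compound 4 `Cc1cncn1CC#CCn1ccn(C)c1=O` is compound 3 with methyl in place of hydrogen on an aromatic carbon.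

Going by the values given here, the one measured step (a 1.5-fold lower number from compound 2 to compound 3 (0.18 log units; within the scatter)) puts 1H-imidazol-1-yl in place of pyrrolidin-1-yl and stays within the scatter. Among the compounds with values here, no measured step adds a methyl, so the data give no direct size for this change, and the expectation is loose. In this assay no shift beyond the scatter is expected in either direction. The estimated change (a 1.3-fold higher number from compound 3 to compound 4 (0.10 log units; within the scatter)) is accordingly small. For compound 4 the expected value is 5.5 mg/kg with an estimated range from 2 mg/kg to 20 mg/kg as its span.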

Compound 4, dose for half-maximal effect: > 100 mg/kg
Compound 4 gave a limit, no number (the forecaster's own chance of this, stated with the estimate: 15%); middle value at least 18-fold (1.25 log units) away from the limit.
By their numbers in this assay, from the lowest: compound 1; then compounds 3 and 2 (each within the scatter of the next). At a limit, above all of these: compound 4.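

In this assay, the imidazole end of the molecule proves sensitive to a very small change: methyl in place of hydrogen on an aromatic carbon, next to the ring nitrogen, gives an at least 22-fold higher number from compound 3 to compound 4 (1.35 log units; beyond the scatter). Going by these compounds alone, the only earlier step at this end of the chain exchanged the whole group and stayed within the scatter, a 1.5-fold lower number from compound 2 to compound 3 (0.18 log units; within the scatter), so it gave no sign that a single added carbon, with no hydrogen-bond donor or acceptor and no net charge, could matter this much. Compound 4 stands at a limit of the assay and not at a number: the limit of > 100 mg/kg in this assay, at which 1 of the 4 values shown sits.

As far as these compounds go, the true size of the step therefore remains unknown. Also open, from the compounds shown here alone, are whether a fluorine or an ethyl group on this carbon would behave like methyl, and whether the same methyl would have a comparable effect in the core of compound 1.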